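Compound 3: methyl on the amine nitrogen

A few compounds are considered here, and "the series" means these few. Any claim that something is new, unique, unknown or untested is made for them only; others in the source may bear on it.

Values in a functional assay on MCF7 cells (Homo sapiens) for antiproliferative activity, read by MTT assay, with a stated time of 48 h (a lower number here means a stronger inhibitor, a higher number a weaker inhibitor), follow.
- compound 1 `COc1ccc(C(=O)c2ccc(OC)c3c2C=CC(C)(C)O3)c(NC(=O)CBr)c1` gives 3290 nM here
- compound 2 `COc1ccc(C(=O)c2ccc(OC)c3c2C=CC(C)(C)O3)c(NC(=O)CN)c1` gives 1250 nM here

Compound 2 (1250 nM) holds the lower of the two numbers. Compound 3 `CNCC(=O)Nc1cc(OC)ccc1C(=O)c1ccc(OC)c2c1C=CC(C)(C)O2` carries methyl in place of hydrogen on an amine nitrogen. For the measured compounds named here, the only measured step (a 2.6-fold lower number from compound 1 to compound 2 (0.42 log units; beyond the scatter)) was modest and put amino in place of bromo, so it does not test methyl on this nitrogen. It offers only a rough scale. No step beyond the scatter is expected in this assay, in either direction, and the expected step is small (a 1.0-fold higher number from compound 2 to compound 3 (0.02 log units; within the scatter)). For compound 3 the estimated value is 1300 nM (range 600 nM to 2800 nM).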

Compound 3, half-maximal inhibitory concentration: 3040 nM
Compound 3: middle estimate off by 2.3-fold (0.37 log units), on the low side, outside the stated range (above it).
By their numbers in this assay, from the lowest: compound 2; then compounds 3 and 1 (each within the scatter of the next).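

In this assay, the amine nitrogen of compound 2 proves sensitive to one added methyl (a 2.4-fold higher number from compound 2 to compound 3 (0.39 log units; beyond the scatter)), so the free amino group matters more here than the small first step suggested. Methylamino in place of bromo brings no clear difference (a 1.1-fold lower number from compound 1 to compound 3 (0.03 log units; within the scatter)), so the advantage of amino over bromo does not carry over to methylamino. No measured evidence explains this result.

Still open, as far as these compounds go, is how dimethylamino, ethylamino or a ring amine such as morpholine would read on this carbon.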